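A few compounds are considered here, and "the series" means these few. Any claim that something is new, unique, unknown or untested is made for them only; others in the source may bear on it.

Measured compounds, cytotoxicity in a functional assay on L1210 cells (Mus musculus) for cytotoxicity, read by cell counting, with a stated time of 2 days; a higher number here means a weaker inhibitor, a lower number a stronger inhibitor:
compound 1 `CC(C)(C)c1ccc(CN2C(=O)S/C(=C\c3ccc(N)cc3)C2=O)cc1`, compound 1 gives 94000 nM
compound 2 `C=C(Br)C(=O)Nc1ccc(/C=C2\SC(=O)N(Cc3cccc(F)c3)C2=O)cc1`, compound 2 gives 1200 nM
compound 3 `C=C(Br)C(=O)Nc1ccc(/C=C2\SC(=O)N(Cc3cccc(Cl)c3)C2=O)cc1`, compound 3 gives 3400 nM

Compound 3 stands second highest of the three numbers in this assay; its nearest neighbour is compound 2, its furthest compound 1, whose number lies far above both of the bromoacrylamide-bearing compounds 2 and 3.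

Compound 4 `C=C(Br)C(=O)Nc1ccc(/C=C2\SC(=O)N(Cc3ccc(C)cc3)C2=O)cc1` has not yet been measured. It differs from compound 3 in one place: 4-methylphenyl in place of 3-chlorophenyl on a saturated chain carbon bound to an amide-type nitrogen in a ring. Within the data shown here, no measured pair covers chloro to methyl, nor a change of position on that phenyl. Among the measured compounds shown here, the only step that bears on the benzyl substituent at all is a 2.8-fold higher number from compound 2 to compound 3 (0.45 log units; beyond the scatter), which shows that the halogen on this phenyl shifts the number modestly. Compound 1 carries a different anilide group as well as a different benzyl, so its gap to compound 3 cannot be assigned to the benzyl alone.

Given that a single-atom change on this phenyl moved the number modestly, a step of similar size in either direction is expected for compound 4, centred close to compound 3, that is a 1.4-fold lower number from compound 3 to compound 4 (0.13 log units; within the scatter). For compound 4 the estimated value in this assay is 2500 nM, with a range of 800 nM to 8000 nM.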

Compound 4, half-maximal inhibitory concentration: 3400 nM
Compound 4: middle estimate off by 1.4-fold (0.13 log units), on the low side; measured number inside the range.
By their numbers in this assay, from the lowest: compound 2; then compounds 3 and 4 (each within the scatter of the next); then compound 1.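

In this assay, 4-methylphenyl in place of 3-chlorophenyl on a saturated chain carbon bound to an amide-type nitrogen in a ring gives no change at the digits printed from compound 3 to compound 4 (within the scatter) and so shows that this position can take a non-halogen group, and a differently placed one, with no shift that stands out from the scatter. Set against the 3-fluorophenyl group, the same 4-methylphenyl gives a 2.8-fold higher number from compound 2 to compound 4 (0.45 log units; beyond the scatter), a step of the same size as a 2.8-fold higher number from compound 2 to compound 3 (0.45 log units; beyond the scatter) and one that leaves compound 2 alone at the low end of the three bromoacrylamide compounds, while compounds 3 and 4 cannot be ordered. No measurement on hand offers an explanation for these numbers.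

In this assay, as far as these compounds go, it remains open whether the phenyl keeps these numbers with an amine or a carboxylic acid in place of the chloro or methyl, or whether a phenethyl group can replace the benzyl. Compound 1 differs from compounds 2, 3 and 4 in more than one place, so the part played by the bromoacrylamide group alone also stays unresolved.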